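Replacing the 4-hydroxycyclohexyl group in compound 3

The compounds below may be only part of what the source reports. "The series", "measured", "known", "first", "only" and "open" are said of these compounds alone.

In a physicochemical assay for solubility (on this read-out lower numbers stand for lower solubility and higher numbers for higher solubility), compound 3 (`CNC(=O)c1cc(C(=O)N[C@H]2CC[C@H](O)CC2)cc2c1OC[C@@]2(C)c1ccccc1`) gives >= 161 ug/mL, which is a limit of the assay and not a number. Its standing among its neighbours therefore cannot be ranked, since the other two values available are limits as well. The change under consideration leads to compound 4 (`CNC(=O)c1cc(C(=O)N[C@H]2[C@@H]3COC[C@@H]32)cc2c1OC[C@@]2(C)c1ccccc1`) and is a group of 6 heavy atoms (5 carbon, 1 oxygen; one three-membered non-aromatic ring of carbon only, one five-membered non-aromatic ring with 1 hetero atom) in place of a group of 7 heavy atoms (6 carbon, 1 oxygen; one six-membered non-aromatic ring of carbon only), on an amide-type nitrogen. Compound 2 (`CNC(=O)c1cc(C(=O)N[C@H]2[C@@H]3C[C@H](O)C[C@@H]32)cc2c1OC[C@@]2(C)c1ccccc1`) differs from compound 3 in the group on that same amide-type nitrogen. Compound 2 gives >= 151 ug/mL, also a limit. Among the measured compounds shown here, the only measured step bearing on the change is a step that the two limits leave unreadable from compound 2 to compound 3, so it supplies no size. Compound 1 (`CNC(=O)c1cc(C(=O)N[C@H]2[C@@H]3COC[C@@H]32)cc2c1OC[C@@]2(CO)c1ccccc1`) carries the entering group on a core that is not the same, and it gives >= 202 ug/mL, again a limit. With no readable size to draw on, no shift beyond the scatter is expected in this assay. The expected change is an at least 1.0-fold lower number from compound 3 to compound 4 (0.03 log units; that floor lies within the scatter). For compound 4 the estimate is 150 ug/mL, with an expected range from 60 ug/mL to 260 ug/mL.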

Compound 4, solubility: >= 147 ug/mL
Compound 4 ended at the assay's limit (the forecaster's own chance of this, stated with the estimate: 60%); the middle value does not contradict the limit.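

In this assay compound 4 gives only a limit, as do compound 1, compound 2 and compound 3, so no step among these compounds can be read. The compounds shown leave open whether exchanging the group on the amide-type nitrogen changes solubility at all.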